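The source may report more compounds than this note shows. Statements on the series, on what has been measured and on what is new or still open speak of the compounds shown alone.

Compound 2 `Brc1ccc([C@@H]2C[C@@H]3Cc4ccc5ccccc5c4N2O3)cc1` is tested in an ADME assay on THP-1 cells (Homo sapiens) for cytotoxicity, read by MTT assay, with a stated time of 72 h; a higher number here means that more compound is tolerated, a lower number that less compound is tolerated. In this assay compound 2 gives > 250000 nM, which is a limit of the assay rather than a measured number. Compound 1 `c1ccc([C@@H]2C[C@@H]3Cc4ccc5ccccc5c4N2O3)cc1` likewise gives > 350000 nM, also a limit. Between these two limits the step that the two limits leave unreadable from compound 1 to compound 2 cannot be read. Compound 3 `Brc1cccc([C@@H]2C[C@@H]3Cc4ccc5ccccc5c4N2O3)c1` differs from compound 2 by 3-bromophenyl in place of 4-bromophenyl on a saturated ring carbon. Among the measured compounds shown here, no measured step bears on this change with a readable size, so no step beyond the usual scatter is expected. The estimated step that the limit leaves unreadable from compound 2 to compound 3 is accordingly set near zero. Compound 3 is expected at 300000 nM, between 150000 nM and 600000 nM, and will most likely again be reported only as a limit.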

Compound 3, half-maximal cytotoxic concentration: > 250000 nM
Compound 3 ended at the assay's limit; the forecaster's own chance of this, stated with the estimate: 90%; the middle value does not contradict the limit.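

In this assay, among the compounds shown here, compound 1, compound 2 and compound 3 all give only limits, so no step among them can be read. The compounds shown leave open at what concentration any of them becomes toxic to these cells.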